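Swapping a small amine substituent for a bulkier carbonyl group

This account rests on a few compounds, and the source may have more. Where it says the series, first, only, none or still open, it means among the compounds named here.

Of the compounds shown here, three sharing one core have been measured in an assay for inhibition of proto-oncogene tyrosine-protein kinase receptor Ret (Homo sapiens), read by 33P incorporation, in the presence of a further agent that is not named here; a higher number here means a weaker inhibitor, a lower number a stronger inhibitor. Compound 2 `CNc1ncc2c(-c3ccc(N4CCN(C)CC4)nc3)nn(CC3CCCC3)c2n1` gives 60 nM. Compound 3 `CCN1CCN(c2ccc(-c3nn(CC4CCCC4)c4nc(NC)ncc34)cn2)CC1` gives 440 nM, and compound 1 `CNc1ncc2c(-c3ccc(N4CCN(C(=O)C(C)(C)C)CC4)nc3)nn(Cc3cn(Cc4ccccc4)nn3)c2n1` gives 4000 nM. Compound 3 therefore stands second highest of the three numbers: its nearest neighbour is compound 2, while compound 1 lies furthest away. Going by the values given here, the single measured step that alters the same region is a 7.3-fold higher number from compound 2 to compound 3 (0.87 log units; beyond the scatter), so enlarging the group on that ring nitrogen already went together with a weaker inhibitor.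

Compound 4 `CNc1ncc2c(-c3ccc(N4CCN(C(=O)C(C)(C)C)CC4)nc3)nn(CC3CCCC3)c2n1` carries a further change at that position: (tert-butyl)carbonyl in place of ethyl on an amine nitrogen in a ring. Among the compounds with values here, no measured pair isolates this exact swap. Compound 1 does bear the same (tert-butyl)carbonyl group and gives the highest number of the three, but it also differs elsewhere, so its value cannot be taken as a clean comparison. Given that lengthening the substituent in the step from compound 2 to compound 3 raised the number, a still larger group is expected to raise it further in this assay, in the same direction and probably by a modest to marked amount, as a 3.4-fold higher number from compound 3 to compound 4 (0.53 log units; beyond the scatter). Compound 4 is thus estimated at 1500 nM, with a plausible range from 300 nM to 8000 nM.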

Compound 4, half-maximal inhibitory concentration: > 10000 nM
Compound 4: only a limit was reported (the forecaster's own chance of this, stated with the estimate: 10%); middle value at least 6.6-fold (0.82 log units) from the limit.
By their numbers in this assay, from the lowest: compound 2; then compound 3; then compound 1. At a limit, above all of these: compound 4.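

In this assay, compound 4 gives only a limit of the assay rather than a number: the limit of > 10000 nM in this assay, at which 1 of the 4 values shown sits. Even so, the limit shows that this position on the ring nitrogen is far less forgiving than the modest 7.3-fold higher number from compound 2 to compound 3 (0.87 log units; beyond the scatter) suggested, since (tert-butyl)carbonyl in place of ethyl gives an at least 22-fold higher number from compound 3 to compound 4 (1.35 log units; beyond the scatter), and in place of methyl it gives an at least 160-fold higher number from compound 2 to compound 4 (2.22 log units; beyond the scatter). The other end of the molecule also matters, as keeping (tert-butyl)carbonyl but having cyclopentyl in place of 1-benzyl-1H-1,2,3-triazol-4-yl gives an at least 2.5-fold higher number from compound 1 to compound 4 (0.39 log units; beyond the scatter), so this group on the ring nitrogen does not by itself settle the reading.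

Going by these compounds, it remains open whether the loss follows the carbonyl or the tert-butyl part, which an acetyl group or a plain tert-butyl group on the same nitrogen would help to separate. On these data alone, it is equally open how 1-benzyl-1H-1,2,3-triazol-4-yl behaves alongside methyl or ethyl on that nitrogen, and whether a free amine there, with hydrogen on the nitrogen, would give a lower number than methyl.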